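The compounds below may be only part of what the source reports. "The series", "measured", "known", "first", "only" and "open" are said of these compounds alone.

Compound 1 `CCN(CC)c1ccc(-c2ccc(C(=O)OC)cc2)nn1`: 250 nM
Compound 2 `CCN(CC)c1ccc(-c2ccc(C(=O)O)cc2)nn1`: > 25000 nM (a limit)

Both results come from a functional assay on Caco-2 cells (Homo sapiens) for antiproliferative activity, with a stated time of 48 h; a higher number here means a weaker inhibitor, a lower number a stronger inhibitor. Compound 2 has no exact number, only the limit > 25000 nM.

Compound 3 `CCOC(=O)c1ccc(-c2ccc(N(CC)CC)nn2)cc1` differs from compound 2 as follows: ethyl in place of hydrogen on an oxygen next to a carbonyl group. Put another way, carboxy gives way to ethoxycarbonyl.

Going by the values given here, one measured step bears on this change: an at least 100-fold higher number from compound 1 to compound 2 (2.00 log units; beyond the scatter). This large step, well beyond the scatter, came from hydrogen replacing methyl at the same place. Compound 3 makes the reverse kind of change, with ethyl instead of methyl. Compound 1 gives 250 nM with methyl on that oxygen, so a large step towards a lower number, meaning a stronger inhibitor, is expected in this assay. The expected size is an at least 83-fold lower number from compound 2 to compound 3 (1.92 log units; beyond the scatter). For compound 3 the estimated value is 300 nM, with an expected range of 90 nM to 1200 nM.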

Compound 3, half-maximal inhibitory concentration: 4000 nM
Estimate against measurement, compound 3: 13-fold (1.12 log units) below; measured number above the stated range.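

Ethyl on the oxygen next to a carbonyl group also gives a stronger inhibitor than the free carboxy group in this assay (an at least 6.2-fold lower number from compound 2 to compound 3 (0.79 log units; beyond the scatter)), so the gain is not confined to methyl. Ethyl does not match methyl, however (a 16-fold higher number from compound 1 to compound 3 (1.20 log units; beyond the scatter)), so it matters which group sits on this oxygen, not only that the hydrogen has been replaced. The first of these steps has no exact size, since compound 2 has only a limit: the limit of > 25000 nM in this assay, at which 1 of the 3 values shown sits.

With only methyl and ethyl on this oxygen, no trend with chain length can be drawn. Going by these compounds, whether a longer chain such as propyl would push the number higher still remains open, as does the effect of an amide in place of the ethoxycarbonyl group.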